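The source may hold more compounds than are shown below. What is called first, only, known or untested is meant among the compounds shown, and "the series" means these compounds.

Measured so far in an assay on membranes from brain for binding affinity to Fatty-acid amide hydrolase 1 (Mus musculus), read by fluorescence, with stated times of 1 h and 30 min; a higher number here means a weaker inhibitor, a lower number a stronger inhibitor: compound 1 `O=C(NCc1ccc(OCc2ccccc2)cc1)n1cccn1` gives 800 nM, and compound 2 `Cc1cnn(C(=O)N2CCCCC2)c1` gives 2200 nM.

Compound 2 thus stands at the higher of the two numbers; the gap to compound 1 is beyond the scatter, so compound 1 is the stronger inhibitor of the pair. The two compounds differ in several places at once, so nothing can be read from that gap about any single change.

Compound 3 `O=C(N1CCCCC1)n1cccn1` differs from compound 2 in one place: hydrogen in place of methyl on an aromatic carbon. For the measured compounds named here, no measured pair shows this change, so the expectation rests on compound 2 alone. The methyl is a single carbon with no donor or acceptor, and its loss is expected to move this assay only a little, if at all, most likely within the scatter, with a slight lean toward a higher number. The expected step is a 1.4-fold higher number from compound 2 to compound 3 (0.13 log units; within the scatter). Compound 3 is therefore estimated at 3000 nM, with a range from 800 nM to 11000 nM.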

Compound 3, half-maximal inhibitory concentration: 1000 nM
Beside the measured number, compound 3's estimate is 3.0-fold (0.48 log units) above it; measured number inside the range.
By their numbers in this assay, from the lowest: compounds 1 and 3 (each within the scatter of the next); then compound 2.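

In this assay, taking the methyl off the aromatic carbon gives a 2.2-fold lower number from compound 2 to compound 3 (0.34 log units; beyond the scatter) and so the methyl is not needed for inhibition in this pair. The position is therefore not silent: this single change shifts the number modestly but beyond the scatter, and the shift favours the compound with hydrogen. No measurement at hand offers an explanation for this step.

This one pair leaves open whether the same change would carry over to a different group on the carbonyl, such as the substituted benzylamine part of compound 1. It also leaves open how larger or different groups on this aromatic carbon, such as an ethyl, a chlorine or a carboxylic acid, would compare with hydrogen on the core of compound 3.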